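The source may hold more compounds than are shown below. What is called first, only, known or untested is meant among the compounds shown, and "the series" means these compounds.

Measured in an ADME assay on HEK293 cells (Homo sapiens) for cytotoxicity, read by luminescence, with a stated time of 72 h; on this read-out higher numbers stand for an effect only at larger amounts of compound and lower numbers for an effect already at smaller amounts:

Compound 1 `CCOC(=O)c1c(-c2cccc(OC(F)(F)F)c2)[nH]c2cc(OC)ccc2c1=O`: > 22000 nM, a limit of the assay.
Compound 2 `CCOC(=O)c1c(-c2cccc(OC)c2)[nH]c2cc(Cl)c(Cl)cc2c1=O`: > 22000 nM, a limit of the assay.
Compound 3 `CCOC(=O)c1c(-c2cccc(OC(F)(F)F)c2)[nH]c2cc(OC)c(F)cc2c1=O`: > 22000 nM, a limit of the assay.

None of the three compounds has a numerical value, so their order in this assay cannot be read. All of them sit at one limit: the limit of > 22000 nM in this assay, at which 3 of the 3 values shown sit. Compound 3 therefore offers a limit as its starting point, not a number.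

Compound 4 `CCOC(=O)c1c(-c2cccc(-c3nc(C)c(C)s3)c2)[nH]c2cc(OC)c(F)cc2c1=O` carries 4,5-dimethyl-1,3-thiazol-2-yl in place of trifluoromethoxy on an aromatic carbon of a six-membered aromatic ring of carbon only, meta to a large group: 4,5-dimethyl-1,3-thiazol-2-yl in place of trifluoromethoxy on an aromatic carbon.

For the measured compounds named here, only one measured step is available, a step that the two limits leave unreadable from compound 1 to compound 3. It is a different change, fluoro in place of hydrogen on an aromatic carbon, and it gives no size to carry over. Going by the values given here, no measured compound pair shows this exchange. The expectation therefore rests on the shared limit, and no step beyond the scatter is confidently expected. A number, if one appears, would be expected to lie close to that limit or somewhat under it. The estimated step is an at least 1.1-fold lower number from compound 3 to compound 4 (0.04 log units; that floor lies within the scatter).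

Compound 4 is estimated at 20000 nM, with an expected range from 8000 nM to 30000 nM.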

Compound 4, half-maximal effective concentration: > 22000 nM
Compound 4: no number, only a limit; the forecaster's own chance of this, stated with the estimate: 70%; middle value at least 1.1-fold (0.04 log units) away from the limit.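

In this assay compound 4 gives > 22000 nM, a limit of the assay and not a number. Compound 3 also sits at a limit, so no step can be read between compound 3 and compound 4: the limit of > 22000 nM in this assay, at which 4 of the 4 values shown sit.

The compounds shown leave open at what concentration, if any, these structures produce an effect in this assay.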